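Swapping the pyrimidine for chloro on the oxazole core

The compounds below may be only part of what the source reports. "The series", "measured", "known", "first", "only" and "open" are said of these compounds alone.

Compound 2 `O=C(CCCCCCc1ccccc1)c1ncc(-c2ccncn2)o1` gives 2.3 nM in an assay (Rattus norvegicus) for inhibition of Fatty-acid amide hydrolase 1 (Homo sapiens) (a higher number here means a weaker inhibitor, a lower number a stronger inhibitor), the only plain number shown. Compound 1 `O=C(CCCCCCc1ccccc1)c1ncc(-c2ncccc2C(=O)O)o1` reaches only the assay limit of > 50 nM in this assay. For the measured compounds named here, the single measured step, an at least 21-fold lower number from compound 1 to compound 2 (1.33 log units; beyond the scatter), concerns a different exchange at the same aromatic carbon and shows only that this group governs potency; the limit of > 50 nM in this assay, at which 1 of the 2 values shown sits, marks where the weaker partner sits. Compound 3 `O=C(CCCCCCc1ccccc1)c1ncc(Cl)o1` differs from compound 2 by chloro in place of pyrimidin-4-yl on an aromatic carbon. Going by the values given here, with no direct precedent, the step is expected to weaken binding, an 87-fold higher number from compound 2 to compound 3 (1.94 log units; beyond the scatter), giving an estimate for compound 3 of 200 nM (range 40 nM to 1000 nM).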

Compound 3, inhibition constant: 5 nM
The estimate for compound 3 lay 40-fold (1.60 log units) above the measured number; the whole stated range lies above it.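

In this assay the exchange gives a 2.2-fold higher number from compound 2 to compound 3 (0.34 log units; beyond the scatter), so at this carbon next to the ring oxygen, most of the potency survives with a single chloro, which has no ring and no hydrogen-bond acceptors. The second new step is an at least 10-fold lower number from compound 1 to compound 3 (1.00 log units; beyond the scatter), which places the 3-carboxypyridin-2-yl group behind even this one atom. For compound 1, > 50 nM is a limit of the assay, so that step has no exact size. The compounds shown leave open how a hydrogen, a methyl or an amine at this carbon would compare with chloro. As far as these compounds go, whether chloro itself adds anything therefore remains unknown.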